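The source may report more compounds than this note shows. Statements on the series, on what has been measured and on what is new or still open speak of the compounds shown alone.

In a functional assay on MDA-MB-231 cells (Homo sapiens) for antiproliferative activity, read by MTT assay, with a stated time of 48 h (on this read-out higher numbers stand for weaker inhibition and lower numbers for stronger inhibition), compound 3 `COc1ccc(NC(=O)N2CCN(c3ncnc4sc(-c5ccc(N6CCN(C)CC6)cc5)cc34)CC2)cc1` gives 20900 nM. Compound 1 `CN1CCN(c2ccc(-c3cc4c(N5CCN(S(=O)(=O)C6CC6)CC5)ncnc4s3)cc2)CC1` gives 11500 nM, a gap of a 1.8-fold higher number from compound 1 to compound 3 (0.26 log units; within the scatter). Compound 2 `CCCNC(=O)N1CCN(c2ncnc3sc(-c4ccc(N5CCN(C)CC5)cc4)cc23)CC1` gives 8330 nM, a gap of a 2.5-fold higher number from compound 2 to compound 3 (0.40 log units; beyond the scatter). Compound 4 `CN1CCN(c2ccc(-c3cc4c(N5CCN(C(=O)Nc6ccc(Cl)cc6)CC5)ncnc4s3)cc2)CC1` differs from compound 3 in one place, with chloro in place of methoxy on an aromatic carbon, para to a large group (chloro in place of methoxy on an aromatic carbon). Among the measured compounds shown here, no measured step makes this swap. The closest evidence is the change at the same end of the molecule, 4-methoxyphenyl in place of propyl, which gave only the modest 2.5-fold higher number from compound 2 to compound 3 (0.40 log units; beyond the scatter). A smaller change should therefore move the number little. The expected step is a 1.4-fold lower number from compound 3 to compound 4 (0.14 log units; within the scatter), slightly downward and not beyond the scatter. For compound 4 the estimated value is 15000 nM, with an expected range of 6000 nM to 35000 nM.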

Compound 4, half-maximal inhibitory concentration: 5440 nM
Compound 4: middle estimate off by 2.8-fold (0.44 log units), on the high side, outside the stated range (below it).
By their numbers in this assay, from the lowest: compounds 4, 2, 1 and 3 (each within the scatter of the next, the first and the last beyond it).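

Within this assay, chloro in place of methoxy on the aromatic carbon para to a large group gives a 3.8-fold lower number from compound 3 to compound 4 (0.58 log units; beyond the scatter) and so shows that this one substituent alone can move the number beyond the scatter. With chloro there, the aryl group is not separated from propyl, with a 1.5-fold lower number from compound 2 to compound 4 (0.19 log units; within the scatter) as the step, while (4-chlorophenyl)carbamoyl in place of cyclopropylsulfonyl gives a 2.1-fold lower number from compound 1 to compound 4 (0.33 log units; beyond the scatter) as a step beyond the scatter. Nothing here gives a reason for these differences. Going by these compounds, whether fluoro, nitrile or an amine at this position would track chloro or methoxy remains open.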